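Sulfonamide nitrogen substituents and maximal aortic response

The compounds below may be only part of what the source reports. "The series", "measured", "known", "first", "only" and "open" are said of these compounds alone.

Compound 1 `CNS(=O)(=O)c1ccc2c(c1)C(n1ccccc1=O)=CC(C)(C)O2`: 85.8%
Compound 2 `CC1(C)C=C(n2ccccc2=O)c2cc(S(=O)(=O)NCCO)ccc2O1`: 95.5%
Compound 3 `CC1(C)C=C(n2ccccc2=O)c2cc(S(=O)(=O)Nc3ccc([N+](=O)[O-])cc3)ccc2O1`: 82.2%

In a functional assay on the whole organism (aorta) with Rattus norvegicus as the target (a higher number here means a larger maximal response, a lower number a smaller maximal response), compound 3 gives the lowest of the three numbers: compound 1 lies within the scatter of it, while compound 2 stands further off, with a number 13.3 percentage points lower from compound 2 to compound 3 (beyond the scatter). Compound 4 `CN(c1ccccc1)S(=O)(=O)c1ccc2c(c1)C(n1ccccc1=O)=CC(C)(C)O2` differs from compound 3 in one place: methyl(phenyl)amino in place of (4-nitrophenyl)amino on a sulfonyl sulfur. Going by the values given here, two measured steps bear on this. The change of the group on the sulfonamide nitrogen gave a number 3.6 percentage points lower from compound 1 to compound 3 (within the scatter) and a number 13.3 percentage points lower from compound 2 to compound 3 (beyond the scatter), so swapping one nitrogen substituent for another has moved this read-out only modestly. Compound 4, carrying a methyl and a phenyl on that nitrogen, is therefore expected to sit close to compound 1, with a number 3.8 percentage points higher from compound 3 to compound 4 (within the scatter) expected. The estimate for compound 4 is 86%, within 76% to 96%.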

Compound 4, largest response reached (Emax), in percent of the reference or control that the assay uses: 64.2%
Compound 4: the middle estimate sits 21.8 percentage points above what was measured; measured number below the stated range.
By their numbers in this assay, from the lowest: compound 4; then compounds 3, 1 and 2 (each within the scatter of the next, the first and the last beyond it).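

Replacing the hydrogen on the sulfonamide nitrogen with phenyl gave a number 21.6 percentage points lower from compound 1 to compound 4 (beyond the scatter) in this assay, and the methyl(phenyl)amino group also gave a number 18 percentage points lower from compound 3 to compound 4 (beyond the scatter) and a number 31.3 percentage points lower from compound 2 to compound 4 (beyond the scatter). Compounds 1, 2 and 3 all keep a hydrogen on that nitrogen, so this position tolerated varied single substituents but lost much of the response once methyl and phenyl were both present. No measurement at hand accounts for this drop.

As far as these compounds go, it remains open whether the methyl or the phenyl matters more, and whether a dimethylamino or morpholine group on the sulfonyl sulfur would give the same fall.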